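The source may hold more compounds than are shown below. What is called first, only, known or untested is meant among the compounds shown, and "the series" means these compounds.

In a functional assay on HO8910 cells (Homo sapiens) for inhibition, read by MTT assay, with a stated time of 24 h, tested at 1 ug/mL (on this read-out higher numbers stand for more inhibition of growth at the one concentration tested and lower numbers for less inhibition of growth), compound 1 `CC(=O)SCCC(CCCCC(=O)O)SC(C)=O` has no single number and is recorded as "not active" (no number reported) without any figure attached. Compound 2 `O=C(CCCCC1CCSS1)Nc1ccccn1` is likewise recorded as "not active" (no number reported) in the same read-out. The only figure in the set comes from compound 3 `O=C(CCCCC(S)CCS)Nc1ccc(F)cc1` with 12.2% of growth inhibition, so the measured compounds span little range. Compound 4 `CC(=O)SCCC(CCCCC(=O)Nc1ccccc1Cl)SC(C)=O` has not yet been measured. It departs from compound 1 in one place, the change being (2-chlorophenyl)amino in place of hydroxy on a carbonyl carbon and thus (2-chlorophenyl)amino in place of hydroxy on a carbonyl carbon. Among the measured compounds shown here, no pair of measured compounds isolates this change, so the data offer no direct guide to the size of the step. A small upward step in this assay is expected, from no recorded activity to weak inhibition, and it may not clearly exceed the usual scatter. For compound 4 the estimated inhibition is 14% with an expected range from 2% to 38% at the single concentration tested.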

Compound 4, percent growth inhibition at one concentration: "not active" (no number reported)
Compound 4: no number reported; no gap can be computed for the estimate.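

Among the compounds shown here, neither compound 1 nor compound 4 carries a number in this assay and so no step between them can be read. Nothing measured here bears on this result. The compounds shown leave open whether (2-chlorophenyl)amino in place of hydroxy changes growth inhibition at all.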